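Third methoxy on the aryl ketone ring

This account rests on a few compounds, and the source may have more. Where it says the series, first, only, none or still open, it means among the compounds named here.

Compound 1 `COc1ccc(-c2cc(/C=C/C(=O)c3cc(OC)c(OC)c(OC)c3)[nH]n2)cc1OC`, compound 2 `COc1ccc(C(=O)/C=C/c2cc(-c3cc(OC)c(OC)c(OC)c3)n[nH]2)cc1` and compound 3 `COc1ccc(C(=O)/C=C/c2cc(-c3cc(OC)c(OC)c(OC)c3)n[nH]2)cc1OC` share one core and differ only in the methoxy pattern on the aryl ketone. In a functional assay on COLO 205 cells (Homo sapiens) for inhibition, read by sulforhodamine B assay, with a stated time of 48 h (a higher number here means a weaker inhibitor of growth, a lower number a stronger inhibitor of growth), compound 1 gives 1750 nM, compound 2 gives 1730 nM and compound 3 gives 1740 nM. Compound 3 holds the second highest of the three numbers, with compound 1 nearest and compound 2 furthest, but both gaps lie within the scatter, so the three cannot be separated.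

Compound 4 `COc1cc(C(=O)/C=C/c2cc(-c3cc(OC)c(OC)c(OC)c3)n[nH]2)cc(OC)c1OC` differs from compound 3 by methoxy in place of hydrogen on an aromatic carbon. Going by the values given here, one measured step bears directly on this change: a 1.0-fold higher number from compound 2 to compound 3 (0.00 log units; within the scatter), the same kind of substitution on the same six-membered aromatic ring of carbon only, which left the number flat. A further methoxy on that ring is therefore expected to give no step beyond the scatter in this assay, the expected step being a 1.0-fold lower number from compound 3 to compound 4 (0.01 log units; within the scatter). Compound 4 is estimated at 1700 nM, within a range of 700 nM to 4200 nM.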

Compound 4, concentration for 50% growth inhibition: 1750 nM
The estimate for compound 4 lay 1.0-fold (0.01 log units) below the measured number; the measured number falls inside the stated range.
By their numbers in this assay, from the lowest: compounds 2, 3, 1 and 4 (each within the scatter of the next).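

In this assay, a further methoxy on the aryl ketone ring, ortho to a methoxy group, gives a 1.0-fold higher number from compound 3 to compound 4 (0.00 log units; within the scatter), so this position takes the group with no step beyond the scatter. Going by these compounds alone, the same substitution read on the second core gives no change at the digits printed from compound 1 to compound 4 (within the scatter), which extends the flat result beyond the single step seen earlier. The change therefore reads the same on both cores: the same change on two cores in this assay, a 1.0-fold higher number (0.00 log units; within the scatter) from compound 2 to compound 3 and no change at the digits printed (within the scatter) from compound 1 to compound 4, 1.0-fold (0.00 log units) apart, within the scatter of two such steps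

The compounds shown carry only hydrogen or methoxy on this ring, so it remains open whether an amine or a carboxylic acid at this position would move the number beyond the scatter. Going by these compounds, a longer chain in place of methoxy remains equally open.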